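This account rests on a few compounds, and the source may have more. Where it says the series, first, only, none or still open, it means among the compounds named here.

Working notes on the series. In a functional assay on Jurkat cells (Homo sapiens) for cytotoxicity, with a stated time of 48 h (a lower number here means a stronger inhibitor, a higher number a weaker inhibitor), compound 1 (`CCOC(=O)CC1C(C(=O)OCC)=C(N)Oc2ccc(Br)cc21`) gives 57300 nM and sits within the scatter of both other measured compounds. Compound 2 (`CCOC(=O)CC1C(C(=O)OCC)=C(N)Oc2cccc(-c3ccccc3)c21`) gives 44300 nM and compound 3 (`CCOC(=O)C1=C(N)Oc2ccc(-c3ccccc3)cc2C1CC(=O)N1CCCCC1`) gives 58500 nM in the same read-out, so the three values form one level with no order among them. The next compound is compound 4 (`CCOC(=O)CC1C(C(=O)OCC)=C(N)Oc2ccc(-c3ccc4ccccc4c3)cc21`), which departs from compound 1 by a single change: naphthalen-2-yl in place of bromo on an aromatic carbon with naphthalen-2-yl in place of bromo on an aromatic carbon. For the measured compounds named here, no measured pair isolates this change. Compound 2 carries a phenyl ring and still gives (44300 nM) at that same level, so a large move is not expected. A modest move toward a lower number in this assay is expected, at or slightly beyond the scatter. The estimated step is a 2.3-fold lower number from compound 1 to compound 4 (0.36 log units; beyond the scatter) on this reading. Compound 4 is estimated at 25000 nM (expected range 8000 nM to 60000 nM).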

Compound 4, half-maximal inhibitory concentration: 18700 nM
Beside the measured number, compound 4's estimate is 1.3-fold (0.13 log units) above it; measured number inside the range.
By their numbers in this assay, from the lowest: compound 4; then compounds 2, 1 and 3 (each within the scatter of the next).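

In this assay, for the compounds shown here, naphthalen-2-yl in place of bromo on this aromatic carbon gives a 3.1-fold lower number from compound 1 to compound 4 (0.49 log units; beyond the scatter), the first single-place change that can be read. The step is modest, but it lies beyond the scatter, so the number at this position does respond to the group it carries, and a group as large as naphthalen-2-yl is accepted without loss of activity. Nothing measured here accounts for the step.

Going by these compounds alone, it remains open whether the second fused ring is needed for the step, as no pair isolates a phenyl ring against naphthalen-2-yl on this carbon. Also open, going by these compounds, is how a non-aromatic group, such as an amine or a carboxylic acid, would read at the same place on the core of compound 1.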